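A few compounds are considered here, and "the series" means these few. Any claim that something is new, unique, unknown or untested is made for them only; others in the source may bear on it.

Measured in an ADME assay on J774.A1 cells (Mus musculus) for cytotoxicity, read by MTT assay, with a stated time of 48 h (a higher number here means that more compound is tolerated, a lower number that less compound is tolerated), so far
compound 1 `O=C(NCc1cccc(Cl)c1Cl)c1c([N+](=O)[O-])noc1-c1ccc([N+](=O)[O-])cc1` gives "not determined" (no result reported)
compound 2 `O=C(NCc1ccc(F)cc1)c1c([N+](=O)[O-])noc1-c1ccc(Cl)cc1` gives 91900 nM
compound 3 `COC(=O)c1c(NCc2ccccc2)noc1-c1ccc([N+](=O)[O-])cc1` gives 85400 nM
compound 4 `CCN(CC)CCNc1noc(-c2ccc([N+](=O)[O-])cc2)c1C(=O)OC` awaits measurement

Compound 3 (85400 nM) lies within the scatter of compound 2 (91900 nM), and compound 1 offers no number for comparison. The change to compound 4 ((diethylamino)methyl in place of phenyl on a saturated chain carbon bound to a nitrogen on an aromatic ring) turns benzylamino into (2-(diethylamino)ethyl)amino. Among the measured compounds shown here, no measured step covers this change, so the expectation is loose: a modest move in this assay towards less compound tolerated, perhaps not beyond the scatter. The expected step is a 1.7-fold lower number from compound 3 to compound 4 (0.23 log units; within the scatter) (an estimate only). For compound 4 the estimated value is 50000 nM (expected range 15000 nM to 120000 nM).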

Compound 4, half-maximal cytotoxic concentration: 69300 nM
Estimate against measurement, compound 4: 1.4-fold (0.14 log units) below; the range from low to high includes it.
By their numbers in this assay, from the lowest: compounds 4, 3 and 2 (each within the scatter of the next).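

In this assay, among the compounds shown here, the first step at this position, (diethylamino)methyl in place of phenyl on a saturated chain carbon bound to a nitrogen on an aromatic ring, reads as a 1.2-fold lower number from compound 3 to compound 4 (0.09 log units; within the scatter) and so stays within the scatter. At this place, then, a chain ending in a tertiary amine and carrying no ring gives a number not separable from that of the benzylamino compound. No data on hand account for this result.

Still open, from the compounds shown here alone, is whether a morpholine ring or a longer chain at this place would give a step beyond the scatter. A single step also cannot show whether the same swap would read alike with a carboxylic acid in place of the methyl ester.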